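The source may report more compounds than this note shows. Statements on the series, on what has been measured and on what is new or still open speak of the compounds shown alone.

Values measured so far in a functional assay on MCF7 cells (Homo sapiens) for cytotoxicity, read by MTT assay, with a stated time of 72 h; on this read-out higher numbers stand for weaker inhibition and lower numbers for stronger inhibition
- Compound 1 `COc1ccc(/C=C/C(=O)Nc2cc3c(Nc4ccc(F)c(Cl)c4)ncnc3cc2O[C@H]2CCOC2)c(OC)c1` gives 28600 nM
- Compound 2 `COc1cc2ncnc(Nc3ccc(F)c(Cl)c3)c2cc1NC(=O)/C=C/c1ccccc1[N+](=O)[O-]` gives 36500 nM
- Compound 3 `COc1ccc(/C=C/C(=O)Nc2cc3c(Nc4ccc(F)c(Cl)c4)ncnc3cc2O[C@H]2CCOC2)c(OC)c1OC` gives 4650 nM

Compound 3 has the lowest of these three numbers, and its gaps to compound 1 and compound 2 both lie beyond the usual scatter. The change from compound 3 to compound 4 `O=C(/C=C/c1ccccc1[N+](=O)[O-])Nc1cc2c(Nc3ccc(F)c(Cl)c3)ncnc2cc1O[C@H]1CCOC1` is 2-nitrophenyl in place of 2,3,4-trimethoxyphenyl on a double-bonded chain carbon bound to a double-bonded chain carbon and it puts 2-nitrophenyl in place of 2,3,4-trimethoxyphenyl on a double-bonded chain carbon bound to a double-bonded chain carbon.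

Among the compounds with values here, the one measured step that bears on this group is a 6.2-fold lower number from compound 1 to compound 3 (0.79 log units; beyond the scatter) with methoxy in place of hydrogen on an aromatic carbon, a modest change in the number. Compound 4 has none of those methoxy groups, so the low number of compound 3 is not expected to carry over. Compound 2 carries the same 2-nitrophenyl and gives 36500 nM as a further guide, though the rest of compound 2 is not identical to compound 4.

The expected step in this assay therefore points to a higher number, about as large as the methoxy step, and is estimated as a 5.4-fold higher number from compound 3 to compound 4 (0.73 log units; beyond the scatter) and so beyond the scatter. For compound 4 the estimated value is 25000 nM with an expected range (9000 nM to 60000 nM).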

Compound 4, half-maximal inhibitory concentration: 28400 nM
Beside the measured number, compound 4's estimate is 1.1-fold (0.06 log units) below it; the range from low to high includes it.
By their numbers in this assay, from the lowest: compound 3; then compounds 4, 1 and 2 (each within the scatter of the next).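

In this assay, putting 2-nitrophenyl in place of 2,3,4-trimethoxyphenyl on this double-bonded chain carbon gives a 6.1-fold higher number from compound 3 to compound 4 (0.79 log units; beyond the scatter) and shows that this position can respond to the group placed there. The comparison with 2,4-dimethoxyphenyl gives a 1.0-fold lower number from compound 1 to compound 4 (0.00 log units; within the scatter) and lies within the scatter, so among these compounds only the 2,3,4-trimethoxyphenyl group stands apart, which fits the earlier methoxy step of a 6.2-fold lower number from compound 1 to compound 3 (0.79 log units; beyond the scatter) and shows that the low number does not extend to the other two groups at this position. With 2-nitrophenyl held constant, oxolan-3-yl in place of methyl on the oxygen gives a 1.3-fold lower number from compound 2 to compound 4 (0.11 log units; within the scatter) and also lies within the scatter, so this second change shows no measurable difference in this pair.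

Nothing available explains why the 2,3,4-trimethoxyphenyl group stands apart. On these data alone, it remains open whether an unsubstituted phenyl or a phenyl carrying an amine or a carboxylic acid would give a low or a high number at this position, and whether exchanging oxolan-3-yl for methyl would matter with 2,3,4-trimethoxyphenyl present.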